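The source may report more compounds than this note shows. Statements on the series, on what has been measured and on what is new or still open speak of the compounds shown alone.

Measured so far:
compound 1, `COc1ccc(-n2cnc3cnc(Oc4cccc(NC(C)=O)c4)cc32)cc1OC`: > 30000 nM in a functional assay on HL-60 cells (Homo sapiens) for activation, read by flow cytometry, with a stated time of 4 days; a higher number here means that more compound is needed for the effect, a lower number that less compound is needed
compound 2, `Fc1ccc(-c2cc3c(cn2)ncn3-c2ccc(OC(F)F)cc2)cc1`: 10000 nM

In this assay compound 1 gives > 30000 nM, and this is a limit of the assay rather than a number. Among the measured compounds shown here, compound 2 gives 10000 nM in this assay and so stands as the only actual number so far. Compound 3, `Cc1cc(Cl)ccc1-c1cc2c(cn1)ncn2-c1ccc(OC(F)F)cc1`, has not yet been measured. Compound 3 differs from compound 2 by 4-chloro-2-methylphenyl in place of 4-fluorophenyl on an aromatic carbon. No measured step of this kind exists among these compounds, so the step of a 2.0-fold lower number from compound 2 to compound 3 (0.30 log units; within the scatter) is expected to be small, toward less compound needed, and barely beyond the usual scatter. Compound 3 is expected at 5000 nM, within 1500 nM to 20000 nM.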

Compound 3, half-maximal effective concentration: 28 nM
Compound 3: middle estimate off by 180-fold (2.25 log units), on the high side; the whole stated range lies above it.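

Replacing 4-fluorophenyl with 4-chloro-2-methylphenyl gives a 360-fold lower number from compound 2 to compound 3 (2.55 log units; beyond the scatter) in this assay. Among the compounds shown here, this aromatic carbon next to the ring nitrogen is therefore a place where a single change of group moves the number strongly, something the earlier compounds could not show, as they offered no step in one place. Nothing measured here bears on why the change has so large an effect.

On these data alone, the new group differs from the old in both its chlorine and its methyl, so which of them matters stays open. Also open, as far as these compounds go, is how an amine or a carboxylic acid on this phenyl ring would fare.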